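Quinoline amide series: furan-2-yl amide in place of bromophenyl

The compounds below may be only part of what the source reports. "The series", "measured", "known", "first", "only" and "open" are said of these compounds alone.

Measured compounds:
compound 1, `CCN1CCN(c2cc(C)c3cc(NC(=O)c4ccc(Br)cc4)ccc3n2)CC1`, 5940 nM
compound 2, `Cc1cc(N2CCN(C)CC2)nc2ccc(NC(=O)c3ccc(Cl)c(Cl)c3)cc12`, 3000 nM
compound 3, `CCN(CC)CCNc1cc(C)c2cc(NC(=O)c3ccc(Cl)c(Cl)c3)ccc2n1`, 1420 nM

In a functional assay on MCF7 cells (Homo sapiens) for antiproliferative activity, read by MTT assay, with a stated time of 72 h (a lower number here means a stronger inhibitor, a higher number a weaker inhibitor), compound 1 gives 5940 nM, the highest of the three numbers. Its nearest neighbour is compound 2, whose 3000 nM lies within the scatter of compound 1; the furthest is compound 3 at 1420 nM, which is beyond the scatter. Within the data shown here, the one measured step, a 2.1-fold lower number from compound 2 to compound 3 (0.32 log units; beyond the scatter), concerns the amine on the shared core and not the amide.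

Compound 4, `CCN1CCN(c2cc(C)c3cc(NC(=O)c4ccco4)ccc3n2)CC1`, is not yet measured. It differs from compound 1 by furan-2-yl in place of 4-bromophenyl on a carbonyl carbon. Among the measured compounds shown here, no measured pair varies the amide aryl group, so nothing in the set bears directly on this change, and its direction is open. The working expectation is a step of a 1.2-fold higher number from compound 1 to compound 4 (0.07 log units; within the scatter), that is, no change beyond the scatter, with a wide range to either side. Compound 4 is therefore estimated at 7000 nM, between 2000 nM and 25000 nM.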

Compound 4, half-maximal inhibitory concentration: 41200 nM
Beside the measured number, compound 4's estimate is 5.9-fold (0.77 log units) below it, outside the stated range (above it).
By their numbers in this assay, from the lowest: compound 3; then compounds 2 and 1 (each within the scatter of the next); then compound 4.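

The amide aryl group is not a silent position: with the amine on the shared core held constant, in this assay the change from 4-bromophenyl to furan-2-yl on the carbonyl carbon gives a 6.9-fold higher number from compound 1 to compound 4 (0.84 log units; beyond the scatter), the first step read at this place, since the earlier step of a 2.1-fold lower number from compound 2 to compound 3 (0.32 log units; beyond the scatter) concerned the amine. Furan-2-yl therefore does not stand in for 4-bromophenyl in this read-out, and the group on this carbonyl carbon moves the number on its own. Nothing at hand bears on what lies behind this rise.

This single pair does not separate the removal of the bromine from the change of ring; a plain phenyl, a 4-chlorophenyl or a thiophen-2-yl on the same carbonyl would divide the two. From the compounds shown here alone, whether the step carries over to compounds with the (2-(diethylamino)ethyl)amino group also stays open.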